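This account rests on a few compounds, and the source may have more. Where it says the series, first, only, none or still open, it means among the compounds named here.

Measured in a functional assay on MDA-MB-231 cells (Homo sapiens) for inhibition, read by MTT assay, with a stated time of 72 h; on this read-out higher numbers stand for weaker inhibition and lower numbers for stronger inhibition:
- compound 1 `c1ccc(-c2nc(CNc3nccc(NC4CC4)n3)cs2)cc1`: > 100000 nM (a limit)
- compound 2 `CCCCN(CCCC)c1ccnc(NCc2csc(-c3ccccc3)n2)n1`: 21700 nM
- compound 3 `c1ccc(-c2nc(CNc3nccc(NC4CCCCC4)n3)cs2)cc1`: 18500 nM

Only compound 2 and compound 3 give actual numbers in this assay, and these two lie within the scatter of each other: a 1.2-fold lower number from compound 2 to compound 3 (0.07 log units; within the scatter). Compound 1 reaches only a limit of the assay.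

The next compound is compound 4 `CCCN(CCC)c1ccnc(NCc2csc(-c3ccccc3)n2)n1`, with dipropylamino in place of cyclohexylamino on an aromatic carbon. Two kinds of measured step bear on this change. Swapping cyclohexylamino for dibutylamino, a group with no ring, made no difference beyond the scatter, as a 1.2-fold lower number from compound 2 to compound 3 (0.07 log units; within the scatter) shows. For the measured compounds named here, this is the closest precedent, since dipropylamino also has no ring. The steps away from cyclopropylamino were larger, at an at least 4.6-fold lower number from compound 1 to compound 2 (0.66 log units; beyond the scatter) and an at least 5.4-fold lower number from compound 1 to compound 3 (0.73 log units; beyond the scatter), but both start from the limit of compound 1 and involve a different group from the one entering here.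

A small shift towards a higher number is therefore expected at most, with no clear change beyond the scatter. The expected step is a 1.5-fold higher number from compound 3 to compound 4 (0.18 log units; within the scatter). For compound 4 the estimated value is 28000 nM, with an expected range of 13000 nM to 65000 nM.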

Compound 4, half-maximal inhibitory concentration: 23200 nM
Estimate against measurement, compound 4: 1.2-fold (0.08 log units) above, within the range that was stated.
By their numbers in this assay, from the lowest: compounds 3, 2 and 4 (each within the scatter of the next). At a limit, above all of these: compound 1.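

In this assay, dipropylamino in place of cyclohexylamino gives a 1.3-fold higher number from compound 3 to compound 4 (0.10 log units; within the scatter), so at this position, next to the ring nitrogen, removing the ring and the hydrogen-bond donor of the entering amino group produces no change that can be told from the scatter. Dipropylamino in place of dibutylamino gives a 1.1-fold higher number from compound 2 to compound 4 (0.03 log units; within the scatter), so the two chain lengths shown cannot be told apart, and compound 2, compound 3 and compound 4 now form one group within the scatter of each other. Dipropylamino in place of cyclopropylamino gives an at least 4.3-fold lower number from compound 1 to compound 4 (0.63 log units; beyond the scatter), a step that starts from the limit of compound 1, so only its minimum size can be read: the limit of > 100000 nM in this assay, at which 1 of the 4 values shown sits.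

The compounds shown leave open whether the gap to compound 1 closes gradually, as a shorter chain such as diethylamino or a mid-sized ring such as cyclopentylamino would show. They also leave open whether any group here moves the number clearly away from this cluster, for instance a morpholine ring, a chain ending in a carboxylic acid, or a longer chain such as dihexylamino.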